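The source may report more compounds than this note shows. Statements on the series, on what has been measured and on what is new or still open speak of the compounds shown alone.

Working notes on the series, all read in a functional assay on HCT-116 cells (Homo sapiens) for cytotoxicity, read by fluorescence, with a stated time of 72 h; a lower number here means a stronger inhibitor, a higher number a weaker inhibitor. Compound 1 `CSc1nc(NCc2ccc(-c3ccccn3)cc2)c2[nH]nc(C(C)C)c2n1`, with methylsulfanyl on an aromatic carbon of the shared core, gives 2800 nM. Compound 2 `CC(C)c1n[nH]c2c(NCc3ccc(-c4ccccn4)cc3)nc(S(C)(=O)=O)nc12`, with methylsulfonyl in that place, gives 1140 nM, which is a 2.5-fold lower number from compound 1 to compound 2 (0.39 log units; beyond the scatter). Compound 3 `CC(C)c1n[nH]c2c(NCc3ccc(-c4ccccn4)cc3)nc(NCCO)nc12`, with (2-hydroxyethyl)amino in that place, gives 27 nM, the lowest of the three numbers. The steps to it are a 100-fold lower number from compound 1 to compound 3 (2.02 log units; beyond the scatter) and a 42-fold lower number from compound 2 to compound 3 (1.63 log units; beyond the scatter).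

Compound 4 `CC(C)c1n[nH]c2c(NCc3ccc(-c4ccccn4)cc3)nc(NCC(C)(C)O)nc12` keeps the amino link and changes the chain: 1-hydroxy-1-methylethyl in place of hydroxymethyl on a saturated chain carbon bound to a nitrogen on an aromatic ring. In words, 1-hydroxy-1-methylethyl stands in place of hydroxymethyl on a saturated chain carbon bound to a nitrogen on an aromatic ring. Among the measured compounds shown here, no measured step alters this chain, so the two large steps bear only indirectly: both concern installing the amino chain, which compound 4 retains. Compound 3 at 27 nM is therefore the anchor, and no step beyond the scatter is expected, with a slight drift to a higher number at most. The expected step is a 1.3-fold higher number from compound 3 to compound 4 (0.11 log units; within the scatter). For compound 4 the estimated value is 35 nM, with an expected range of 12 nM to 100 nM.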

Compound 4, half-maximal inhibitory concentration: 85 nM
Compound 4: the middle estimate sits 2.4-fold (0.39 log units) below what was measured; measured number inside the range.
By their numbers in this assay, from the lowest: compound 3; then compound 4; then compound 2; then compound 1.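

In this assay, 1-hydroxy-1-methylethyl in place of hydroxymethyl gives a change beyond the scatter (a 3.1-fold higher number from compound 3 to compound 4 (0.50 log units; beyond the scatter)), so the chain itself matters, although the counts of hydrogen-bond donors and acceptors stay the same and only the heavy-atom count rises. Most of the gain from the amino link survives the larger chain (a 13-fold lower number from compound 2 to compound 4 (1.13 log units; beyond the scatter); a 33-fold lower number from compound 1 to compound 4 (1.52 log units; beyond the scatter)), so (2-hydroxy-2-methylpropyl)amino still stands well clear of both methylsulfonyl and methylsulfanyl. No measurement of any property of these compounds bears on this result.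

The compounds shown leave open whether a 2-hydroxypropyl chain, carrying a single added methyl, would sit with compound 3 or with compound 4. They also leave open whether the hydroxyl is needed at all, which a 2-methoxyethyl or plain propyl chain would test.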